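Replacing 2-methylpiperidin-1-yl with dimethylamino on a sulfonyl sulfur

This account rests on a few compounds, and the source may have more. Where it says the series, first, only, none or still open, it means among the compounds named here.

In an in vitro ADME assay on microsomes from liver (Rattus norvegicus) for metabolic stability, read by LC-MS, tested at 1 uM (a higher number here means faster removal of the compound, a lower number slower removal), compound 3 `Cc1ccc(S(=O)(=O)N2CCCCC2C)cc1C#Cc1cc(Cl)ccc1OCC(=O)O` gives 418 mL.min-1.g-1 and stands highest of the three measured compounds. Compound 1 `COCCN(C)S(=O)(=O)c1ccc(C)c(C#Cc2cc(Cl)ccc2OCC(=O)O)c1` gives 49 mL.min-1.g-1 and compound 2 `Cc1ccc(S(=O)(=O)N(C)C(C)C)cc1C#Cc1cc(Cl)ccc1OCC(=O)O` gives 64 mL.min-1.g-1, two numbers that sit close together (a 1.3-fold higher number from compound 1 to compound 2 (0.12 log units; within the scatter)). Compound 4 `Cc1ccc(S(=O)(=O)N(C)C)cc1C#Cc1cc(Cl)ccc1OCC(=O)O` is still unmeasured and carries dimethylamino in place of 2-methylpiperidin-1-yl on a sulfonyl sulfur. Two measured steps put that same 2-methylpiperidin-1-yl in place of a ringless amino group (an 8.5-fold higher number from compound 1 to compound 3 (0.93 log units; beyond the scatter)) and (a 6.5-fold higher number from compound 2 to compound 3 (0.81 log units; beyond the scatter)). Compound 4 has no ring there either, so an estimated drop of similar size is expected (a 9.3-fold lower number from compound 3 to compound 4 (0.97 log units; beyond the scatter)). The expected value for compound 4 is 45 mL.min-1.g-1 with 18 mL.min-1.g-1 to 110 mL.min-1.g-1 as its estimated range.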

Compound 4, intrinsic clearance in microsomes: 22 mL.min-1.g-1
Estimate against measurement, compound 4: 2.0-fold (0.31 log units) above, within the range that was stated.
By their numbers in this assay, from the lowest: compound 4; then compounds 1 and 2 (each within the scatter of the next); then compound 3.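

In this assay, dimethylamino on the sulfonyl sulfur gives the lowest number of the four compounds, and swapping the ring for it is the largest step here (a 19-fold lower number from compound 3 to compound 4 (1.28 log units; beyond the scatter)). The ringless groups also separate from one another (a 2.9-fold lower number from compound 2 to compound 4 (0.46 log units; beyond the scatter)) and (a 2.2-fold lower number from compound 1 to compound 4 (0.35 log units; beyond the scatter)). So having no ring at this position does not fix the number by itself, since the choice of ringless group still moves it beyond the scatter.

Nothing available explains these differences. Going by these compounds, whether piperidin-1-yl, without the methyl, or the smaller pyrrolidin-1-yl would sit near compound 3 or near the ringless compounds remains open.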